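A few compounds are considered here, and "the series" means these few. Any claim that something is new, unique, unknown or untested is made for them only; others in the source may bear on it.

Measured so far in an ADME assay on the whole organism (blood, strain Han-Wistar) for pharmacokinetics, with Rattus norvegicus as the target, read by LC-MS, at a dose of 1 mg/kg by the intravenous route; a lower number here means slower removal, a higher number faster removal of the compound:
- compound 1 `Cc1ccc([C@@H](C)Oc2cc3onc(CCC(=O)O)c3cc2Cl)nn1`: 12 mL/min/kg
- compound 2 `C[C@@H](Oc1cc2onc(CCC(=O)O)c2cc1Cl)c1ccc(Cl)cn1`: 0.35 mL/min/kg

For the measured compounds named here, compound 2 holds the lower of the two numbers, at 0.35 mL/min/kg in this assay, and compound 1 is the only neighbour. The next compound is compound 3 `C[C@@H](Oc1cc2onc(CCC(=O)O)c2cc1Cl)c1ccccn1`, which differs from compound 2 in one place: hydrogen in place of chloro on an aromatic carbon. Hydrogen stands in place of chloro on an aromatic carbon, para to a large group.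

Going by the values given here, only one measured step bears on this, a 34-fold lower number from compound 1 to compound 2 (1.54 log units; beyond the scatter), which is large and beyond the scatter. That step exchanged 6-methylpyridazin-3-yl for 5-chloropyridin-2-yl as a whole, so it does not separate the chloro from the rest of the exchange. Among the compounds with values here, no measured pair isolates the chloro. Part of the large step from compound 1 may therefore be lost, and a move to a higher number is expected, though a smaller one than that step. The estimated step is a 4.3-fold higher number from compound 2 to compound 3 (0.63 log units; beyond the scatter). For compound 3 the expected clearance is 1.5 mL/min/kg, with an estimated range of 0.5 mL/min/kg to 5 mL/min/kg.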

Compound 3, clearance in the Rattus norvegicus assay: 0.8 mL/min/kg
Estimate against measurement, compound 3: 1.9-fold (0.27 log units) above; low and high end bracket the measured number.
By their numbers in the Rattus norvegicus assay, from the lowest: compound 2; then compound 3; then compound 1.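

In the Rattus norvegicus assay, the chloro of the 5-chloropyridin-2-yl group is now separated from the rest of the ring exchange, and taking it away gives a 2.3-fold higher number from compound 2 to compound 3 (0.36 log units; beyond the scatter), a modest step beyond the scatter. The ring exchange without the chloro still gives a 15-fold lower number from compound 1 to compound 3 (1.18 log units; beyond the scatter), so in this set the larger part of the gap to compound 1 stays with pyridin-2-yl in place of 6-methylpyridazin-3-yl, and the chloro on this aromatic carbon, para to a large group, adds a smaller part. In a physicochemical assay for pharmacokinetics, at pH 6 (a higher number here means that the compound lasts longer, a lower number that the compound disappears faster), compound 2 gives > 1000 h as a limit of the assay and not as a number. In the physicochemical assay compound 3 gives > 1000 h as a limit of the assay and not as a number. In the physicochemical assay, the same change from chloro to hydrogen cannot be read, since both compounds stand at a limit and not at a number: the limit of > 1000 h in the physicochemical assay, at which 2 of the 2 values shown sit.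

Still open, as far as these compounds go, is how fluoro, methyl or a nitrile on the same aromatic carbon would compare with chloro and hydrogen in the Rattus norvegicus assay. Also open, from the compounds shown here alone, is how the step from compound 1 divides between the methyl of 6-methylpyridazin-3-yl and the ring that carries it.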